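Chloro substitution on two related cores

The compounds below may be only part of what the source reports. "The series", "measured", "known", "first", "only" and "open" are said of these compounds alone.

Compound 1 `Cc1[nH]c2ccccc2c(=O)c1Br` and compound 2 `Cc1[nH]c2ccc(Cl)cc2c(=O)c1Br` share one core; compound 3 `CCCCC#Cc1c(C)[nH]c2ccccc2c1=O` and compound 4 `CCCCC#Cc1c(C)[nH]c2ccc(Cl)cc2c1=O` share another. In a physicochemical assay for lipophilicity, at pH 7.4 (on this read-out higher numbers stand for higher lipophilicity and lower numbers for lower lipophilicity), compound 1 gives 1.67, and compound 2 gives 2.02. The change between them is chloro in place of hydrogen on an aromatic carbon, and it made the step of a number 0.35 log units higher from compound 1 to compound 2 (beyond the scatter). The two cores differ by hex-1-yn-1-yl in place of bromo on an aromatic carbon; in this assay compound 3 gives 5.44, the step being a number 3.77 log units higher from compound 1 to compound 3 (beyond the scatter), which leaves compound 3 the highest of the three measured values. Compound 4 is not yet measured in this assay. It differs from compound 3 by chloro in place of hydrogen on an aromatic carbon; the place is described in the same words as for compound 1 and compound 2, so this is the same change, occurring twice among these four compounds. For compound 4 the expected step is a number 0.36 log units higher from compound 3 to compound 4 (beyond the scatter), set next to the measured a number 0.35 log units higher from compound 1 to compound 2 (beyond the scatter), the only pairing that shows this change; a second core offers no check on it, so the expectation rests on that single case. Compound 4 is accordingly estimated at 5.8, with a range from 5.4 to 6.2.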

Compound 4, distribution coefficient: 2.98
The estimate for compound 4 lay 2.82 log units above the measured number; measured number outside the range, below it.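

In this assay, chloro in place of hydrogen on an aromatic carbon gives a number 2.46 log units lower from compound 3 to compound 4 (beyond the scatter) but a number 0.35 log units higher from compound 1 to compound 2 (beyond the scatter) on the other core, so the same change runs in opposite directions and the step on the core of compound 1 does not carry over to the core of compound 3. Hex-1-yn-1-yl in place of bromo likewise depends on its surroundings, giving a number 0.96 log units higher from compound 2 to compound 4 (beyond the scatter) where chloro is present and a number 3.77 log units higher from compound 1 to compound 3 (beyond the scatter) where it is absent, but with one pairing per core this shows only that the two changes do not add up in these four compounds, not how chloro would behave on any further core. Nothing available bears on the reason for the reversal.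

As far as these compounds go, it remains open whether the reversal persists when hex-1-yn-1-yl gives way to a shorter chain, a longer chain, an amine or a carboxylic acid. From the compounds shown here alone, it also remains open whether fluoro or methoxy at the same place would follow chloro on either core.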